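Furan-2-yl for Pyridin-4-yl: Expecting a Small Step

A few compounds are considered here, and "the series" means these few. Any claim that something is new, unique, unknown or untested is made for them only; others in the source may bear on it.

Measured in an assay on CHO cells for displacement of a labelled ligand from 5-hydroxytryptamine receptor 1D (Homo sapiens); a lower number here means a stronger inhibitor, a higher number a weaker inhibitor:
Compound 1 `c1ccc(CN2CCN(CCCc3c[nH]c4ccc(-n5cnnc5)cc34)CC2)nc1`: 0.4 nM
Compound 2 `c1cc(CN2CCN(CCCc3c[nH]c4ccc(-n5cnnc5)cc34)CC2)ccn1`: 0.6 nM

Compound 2 holds the higher of the two numbers, but a 1.5-fold higher number from compound 1 to compound 2 (0.18 log units; within the scatter) lies within the scatter, so the two are not separated. Compound 3 `c1coc(CN2CCN(CCCc3c[nH]c4ccc(-n5cnnc5)cc34)CC2)c1` differs from compound 2 by furan-2-yl in place of pyridin-4-yl on a saturated chain carbon bound to an amine nitrogen in a ring. Among the compounds with values here, the only comparable step, a 1.5-fold higher number from compound 1 to compound 2 (0.18 log units; within the scatter), also exchanged the ring at this place and stayed within the scatter, so no change beyond the scatter is expected in this assay. Compound 3 is therefore estimated at 0.9 nM, between 0.3 nM and 3 nM, an expected 1.5-fold higher number from compound 2 to compound 3 (0.18 log units; within the scatter).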

Compound 3, half-maximal inhibitory concentration: 0.4 nM
Beside the measured number, compound 3's estimate is 2.3-fold (0.35 log units) above it, and the stated range covers the measured number.
By their numbers in this assay, from the lowest: compounds 1, 3 and 2 (each within the scatter of the next).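

In this assay the ring at this place need not be six-membered or contain nitrogen: furan-2-yl, a five-membered ring with oxygen, gives a 1.5-fold lower number from compound 2 to compound 3 (0.18 log units; within the scatter) and also no change at the digits printed from compound 1 to compound 3 (within the scatter). Across these three compounds, then, the exchange of one aromatic ring for another leaves the number within the scatter. Nothing measured here explains this. Still open, on these data alone, is whether the hetero atom matters at all, which a phenyl ring would test, and whether an aromatic ring is needed, which cyclohexyl would test.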